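The source may report more compounds than this note shows. Statements on the series, on what has been measured and on what is new or still open speak of the compounds shown alone.

Compound 1, `COc1ccc(CNc2cc(OC)c(OC)c(OC)c2)cc1C`: 60900 nM. Compound 2, `C=C(C)C(=O)N(Cc1ccc(OC)c(O)c1)c1cc(OC)c(OC)c(OC)c1`: 200 nM. Compound 3, `C/C=C/C(=O)N(Cc1ccc(OC)cc1)c1cc(OC)c(OC)c(OC)c1`: 500 nM.

All three values come from a functional assay on HCT-116 cells (Homo sapiens) for inhibition, read by MTT assay, with a stated time of 48 h; a lower number here means a stronger inhibitor, a higher number a weaker inhibitor. Compound 2 has the lowest number of the three; compound 3 is nearest to it and still beyond the scatter, while compound 1 lies very far above. Compound 4, `CC/C=C/C(=O)N(Cc1ccc(OC)c(O)c1)c1cc(OC)c(OC)c(OC)c1`, is not yet measured. It differs from compound 2 in one place: but-1-en-1-yl in place of 1-methylethenyl on a carbonyl carbon. Going by the values given here, no measured pair shows this exact change, so the expectation rests only on the values of compound 2 and compound 3, which show that amides of this core with different small unsaturated chains stay in the same potent region. The step of a 1.8-fold higher number from compound 2 to compound 4 (0.24 log units; within the scatter) is expected to be modest, towards a higher number, at the edge of the scatter. Compound 4 is therefore expected near 350 nM, between 120 nM and 1000 nM.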

Compound 4, half-maximal inhibitory concentration: 63 nM
Estimate against measurement, compound 4: 5.6-fold (0.74 log units) above; measured number outside the range, below it.
By their numbers in this assay, from the lowest: compound 4; then compound 2; then compound 3; then compound 1.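

Replacing 1-methylethenyl with but-1-en-1-yl on a carbonyl carbon gives a 3.2-fold lower number from compound 2 to compound 4 (0.50 log units; beyond the scatter) in this assay and places this step beyond the scatter. This position therefore still responds to a small change in the chain, from 3 heavy atoms to 4, with one double bond kept outside the rings and the rest of the molecule unchanged. Nothing measured here explains the step.

On these data alone, whether a longer chain such as hex-1-en-1-yl would lower the number further remains open. So does the effect of a saturated butyl chain or a chain ending in an amine.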